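The source may hold more compounds than are shown below. What is called first, only, known or untested is meant among the compounds shown, and "the series" means these compounds.

Compound 1 `CS(=O)(=O)Oc1c(C(=O)NCc2ccc(F)cc2)nc(Br)c2cccnc12`: > 20000 nM
Compound 2 `Nc1cccc(Nc2c(C(=O)NCc3ccc(F)cc3)nc(Br)c3cccnc23)c1`: > 10000 nM
Compound 3 `C[C@@H](Nc1c(C(=O)NCc2ccc(F)cc2)nc(Br)c2cccnc12)c1ccccc1`: > 20000 nM

All three results come from a functional assay on HCT-116 cells (Homo sapiens) for cytotoxicity, read by MTT assay, with a stated time of 72 h (a lower number here means a stronger inhibitor, a higher number a weaker inhibitor), and each one is a limit of the assay, not a number. One result sits at the limit of > 10000 nM in this assay, at which 1 of the 3 values shown sits. The other two sit at the limit of > 20000 nM in this assay, at which 2 of the 3 values shown sit. Compound 3 therefore stands only at a limit, > 20000 nM.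

Compound 4 `Nc1ccc(Nc2c(C(=O)NCc3ccc(F)cc3)nc(Br)c3cccnc23)cc1` brings one structural change: 4-aminophenyl in place of 1-phenylethyl on a nitrogen on an aromatic ring. Put simply, 4-aminophenyl takes the place of 1-phenylethyl on a nitrogen on an aromatic ring.

Among the measured compounds shown here, three measured steps bear on this: a step that the two limits leave unreadable from compound 1 to compound 2, a step that the two limits leave unreadable from compound 1 to compound 3 and a step that the two limits leave unreadable from compound 2 to compound 3. None of them has a size that can be read, so they give no firm direction. The best guide is compound 2, which carries 3-aminophenyl on that nitrogen and still gives only a limit, > 10000 nM.

No clear gain in this assay is therefore expected, and the result may well be another limit. The expected move is an at least 1.4-fold lower number from compound 3 to compound 4 (0.15 log units; that floor lies within the scatter). Compound 4 is estimated at 14000 nM, with an expected range of 5000 nM to 30000 nM.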

Compound 4, half-maximal inhibitory concentration: 10000 nM
Beside the measured number, compound 4's estimate is 1.4-fold (0.15 log units) above it, and the stated range covers the measured number.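

In this assay, among the compounds shown here, only one of the four compounds gives a number and not a limit, and 4-aminophenyl in place of 3-aminophenyl on the nitrogen gives a number no higher from compound 2 to compound 4 (the limit leaves the size open). The change on the nitrogen gives an at least 2.0-fold lower number from compound 3 to compound 4 (0.30 log units; that floor lies within the scatter) and the exchange of (methylsulfonyl)oxy for (4-aminophenyl)amino gives an at least 2.0-fold lower number from compound 1 to compound 4 (0.30 log units; that floor lies within the scatter) as its counterpart, so both steps are floors only and neither shows a firm gain. The size of the step between 3-aminophenyl and 4-aminophenyl cannot be read, so these two groups cannot be ranked.

From the compounds shown here alone, it remains open whether the amino group matters at all or whether the aromatic ring alone gives this result, a question that plain phenyl on the nitrogen would address. Also open, going by these compounds, is whether a longer chain ending in an amine would give a lower number.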